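This account rests on a few compounds, and the source may have more. Where it says the series, first, only, none or still open, it means among the compounds named here.

In an ADME assay on cells (Rhabdomyosarcoma cell, Homo sapiens) for cytotoxicity, read by MTT assay, with a stated time of 72 h (a lower number here means that less compound is tolerated, a higher number that more compound is tolerated), three compounds have been measured so far. Compound 1 `Nc1sc2c(c1-c1nc3cc(Cl)ccc3s1)CCC2` gives 59.1 ug/mL. Compound 2 `Clc1ccc(/C=N/c2sc3c(c2-c2nc4ccccc4s2)CCC3)c(Cl)c1` gives 160 ug/mL, and compound 3 `Clc1ccc(/C=N/c2sc3c(c2-c2nc4ccccc4s2)CCCC3)c(Cl)c1` gives 56.6 ug/mL. Compound 3 thus has the lowest number of the three: its value sits within the scatter of compound 1, while compound 2 stands beyond the scatter at a higher number.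

Compound 4 `O=[N+]([O-])c1ccccc1/C=N/c1sc2c(c1-c1nc3ccccc3s1)CCCC2` has not yet been measured in this assay. Compared with compound 3, compound 4 carries 2-nitrophenyl in place of 2,4-dichlorophenyl on a carbon with a double bond to nitrogen, that is, 2-nitrophenyl in place of 2,4-dichlorophenyl on a carbon with a double bond to nitrogen. Among the compounds with values here, no pair of measured compounds shows this change, so the available numbers give no direct guide to its size. The step of a 1.1-fold higher number from compound 3 to compound 4 (0.03 log units; within the scatter) is expected to stay within the scatter, with no clear direction. The estimate for compound 4 in this assay is 60 ug/mL, with a range from 25 ug/mL to 150 ug/mL.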

Compound 4, half-maximal cytotoxic concentration: 255 ug/mL
The estimate for compound 4 lay 4.3-fold (0.63 log units) below the measured number; the measured number lies above the stated range.
By their numbers in this assay, from the lowest: compounds 3 and 1 (each within the scatter of the next); then compounds 2 and 4 (each within the scatter of the next).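

In this assay, replacing 2,4-dichlorophenyl with 2-nitrophenyl on a carbon with a double bond to nitrogen gives a 4.5-fold higher number from compound 3 to compound 4 (0.65 log units; beyond the scatter) and is the first single-place change among these compounds. It shows that the group at this place can by itself move the number beyond the scatter, with the rest of the molecule unchanged. Nothing available explains why the number rises with this exchange.

This single pair cannot separate the arrival of the nitro group from the departure of the two chlorines, and a plain phenyl or a phenyl carrying an amine or a carboxylic acid at this place would be needed to tell them apart. As far as these compounds go, whether the same exchange has a similar effect on the core of compound 2 also remains open.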